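This account rests on a few compounds, and the source may have more. Where it says the series, first, only, none or still open, it means among the compounds named here.

Measured compounds, in a physicochemical assay for solubility, read by HPLC, in phosphate buffer, measured as thermodynamic solubility, with a stated time of 24 h, at pH 6.8; on this read-out higher numbers stand for higher solubility and lower numbers for lower solubility:
- compound 1 `CCNC(=O)c1ccc(-c2cc3nnn(C4CCN(c5ncc(CC)cn5)CC4)c3cn2)c(Cl)c1`: 240 nM
- compound 2 `CCNC(=O)c1ccc(-c2cc3nnn(C4CCN(c5ncc(CC)cn5)CC4)c3cn2)c(C(F)(F)F)c1`: 1200 nM
- compound 3 `CCNC(=O)c1ccc(-c2cc3nnn(C4CCN(c5ncc(CC)cn5)CC4)c3cn2)cc1Cl`: a limit, < 160 nM

Compound 3 gives only a limit in this assay, < 160 nM, which is the limit of < 160 nM in this assay, at which 1 of the 3 values shown sits. Compound 2 differs from compound 1 by trifluoromethyl in place of chloro on an aromatic carbon, and the measured step is a 5.0-fold higher number from compound 1 to compound 2 (0.70 log units; beyond the scatter).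

Compound 4 `CCNC(=O)c1ccc(-c2cc3nnn(C4CCN(c5ncc(CC)cn5)CC4)c3cn2)cc1C(F)(F)F` is not yet measured in this assay. It differs from compound 3 by trifluoromethyl in place of chloro on an aromatic carbon. This is the same kind of change as that from compound 1 to compound 2, but not the same: in the first pair the site is ortho to a large group and meta to an ethylcarbamoyl group, whereas in compound 3 to compound 4 it is ortho to an ethylcarbamoyl group and meta to a large group. The difference between the core of compound 3 and the core of compound 1 is not broken down here; the two have the same atoms, joined differently.

Among the compounds with values here, for compound 4 in this assay the expected step is an at least 2.5-fold higher number from compound 3 to compound 4 (0.39 log units; beyond the scatter), resting on the measured step of a 5.0-fold higher number from compound 1 to compound 2 (0.70 log units; beyond the scatter) as the only precedent for this change. Because compound 3 stands at a limit, < 160 nM, the starting point is itself uncertain, and the expectation is correspondingly wide. Compound 4 is estimated at 400 nM, expected to lie between 150 nM and 1200 nM.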

Compound 4, solubility: 510 nM
For compound 4 the middle estimate is 1.3-fold (0.11 log units) below the measured one; the measured number falls inside the stated range.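

In this assay, trifluoromethyl in place of chloro gives an at least 3.1-fold higher number from compound 3 to compound 4 (0.50 log units; beyond the scatter), and the same change on the core of compound 1 gives a 5.0-fold higher number from compound 1 to compound 2 (0.70 log units; beyond the scatter), so the read-out moves the same way, and beyond the scatter, on both cores shown. Compound 3 gives only a limit and not a number, < 160 nM, so the full size of the new step cannot be read, and the two steps cannot be called equal or different in size: the limit of < 160 nM in this assay, at which 1 of the 4 values shown sits. This is one transfer across two cores, and the site in compound 4, ortho to an ethylcarbamoyl group and meta to a large group, is not the site in compound 2, so the agreement in direction sets no general rule and gives no transferable step size.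

The compounds shown leave open whether other groups at this site, such as an amine, a carboxylic acid or a nitrile, would move the read-out in the same way on both cores. They also leave open how a longer chain in place of the ethyl on the amide or on the far ring would behave alongside trifluoromethyl or chloro.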